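A few compounds are considered here, and "the series" means these few. Any claim that something is new, unique, unknown or untested is made for them only; others in the source may bear on it.

In an ADME assay on microsomes from liver (Mus musculus) for metabolic stability, with a stated time of 10 min, tested at 0.5 uM (a lower number here means that less of the compound is left, a higher number that more of the compound is left), compound 1 `C[C@H](NC(=O)[C@H](C)[C@H]1CC[C@@H](c2ccnc3ccc(F)cc32)CC1)c1ccc(Cl)cc1` gives 5% and compound 2 `C[C@@H](NC(=O)Nc1ccc(Cl)cc1)[C@H]1CC[C@@H](c2ccnc3ccc(F)cc32)CC1` gives 14% and these two numbers lie within the usual scatter of each other, with little of either compound left. Compound 3 `C[C@@H](NC(=O)C12CCC(Cl)(CC1)CC2)[C@H]1CC[C@@H](c2ccnc3ccc(F)cc32)CC1` differs from compound 2 in one place, on a carbonyl carbon, where the change is a group of 9 heavy atoms (8 carbon, 1 chlorine; 2 six-membered non-aromatic rings of carbon only) in place of a group of 8 heavy atoms (6 carbon, 1 nitrogen, 1 chlorine; one six-membered aromatic ring of carbon only), on a carbonyl carbon and the rest of the molecule stays the same. Among the compounds with values here, no measured pair shows what such a swap does, so the expected step of a number 2 percentage points lower from compound 2 to compound 3 (within the scatter) is estimated to stay within the scatter, with no firm direction. In this assay the estimate for compound 3 is 12% with an expected range from 3% to 35% around it.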

Compound 3, percent of the compound remaining: 10%
Beside the measured number, compound 3's estimate is 2 percentage points above it; the range from low to high includes it.
By their numbers in this assay, from the lowest: compounds 1, 3 and 2 (each within the scatter of the next).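

In this assay the change on this carbonyl carbon gives a number 4 percentage points lower from compound 2 to compound 3 (within the scatter) and so shows that two six-membered non-aromatic rings can stand in for the (4-chlorophenyl)amino group without a readable shift. The amide-type nitrogen of that group, with its hydrogen-bond donor, is gone from this place, and the amount of compound left still does not move beyond the scatter. From the compounds shown here alone, whether another group on this carbonyl carbon, such as a morpholine ring, would leave clearly more of the compound stays open. Nothing measured here offers an explanation for this result.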